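This account rests on a few compounds, and the source may have more. Where it says the series, first, only, none or still open, it means among the compounds named here.

The three measured compounds in a functional assay on MV4-11 cells (Homo sapiens) for inhibition, read by resazurin assay, with a stated time of 72 h (on this read-out higher numbers stand for weaker inhibition of growth and lower numbers for stronger inhibition of growth), are:

Compound 1, `COCCOc1nc(C)c(-c2ccnc(Nc3ccc(OC)cc3OC)n2)s1`: 1980 nM
Compound 2, `COc1ccc(Nc2nccc(-c3sc(OC(C)C)nc3C)n2)c(OC)c1`: 8690 nM
Compound 3, `COCCSc1nc(C)c(-c2ccnc(Nc3ccc(OC)cc3OC)n2)s1`: 810 nM

On these numbers compound 3 stands lowest, and therefore inhibits growth most strongly; the nearest is compound 1 (a 2.4-fold lower number from compound 1 to compound 3 (0.39 log units; beyond the scatter)), the furthest compound 2 (an 11-fold lower number from compound 2 to compound 3 (1.03 log units; beyond the scatter)). The step from compound 1 to compound 2 (a 4.4-fold higher number from compound 1 to compound 2 (0.64 log units; beyond the scatter)) shows that a smaller, plain alkyl group on the oxygen at this place costs activity.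

Compound 4, `CCOc1nc(C)c(-c2ccnc(Nc3ccc(OC)cc3OC)n2)s1`, is not yet measured. It differs from compound 3 in one place: ethoxy in place of (2-methoxyethyl)sulfanyl on an aromatic carbon. Going by the values given here, two parts of the earlier steps bear on this. Trading the sulfur link for an oxygen link, as from compound 3 to compound 1, gave a modest rise in the number; trading the 2-methoxyethyl chain for a plain alkyl group, as from compound 1 to compound 2, gave a further modest rise. Compound 4 combines both, though its ethoxy group is smaller than isopropoxy, so the expected step in this assay is a rise, probably larger than either single step, landing between compound 1 and compound 2.

Compound 4 is therefore expected to give about 3000 nM, with a range from 1200 nM to 8000 nM, which corresponds to an expected step of a 3.7-fold higher number from compound 3 to compound 4 (0.57 log units; beyond the scatter).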

Compound 4, concentration for 50% growth inhibition: 3890 nM
Compound 4: the middle estimate sits 1.3-fold (0.11 log units) below what was measured; the measured number falls inside the stated range.
By their numbers in this assay, from the lowest: compound 3; then compounds 1 and 4 (each within the scatter of the next); then compound 2.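

Taking one methyl off isopropoxy to leave ethoxy gives a lower number (a 2.2-fold lower number from compound 2 to compound 4 (0.35 log units; beyond the scatter)), so in this assay the shape of a plain alkyl group on this oxygen matters. Taking the methoxy end off 2-methoxyethoxy, by contrast, leaves the two numbers within the usual scatter (a 2.0-fold higher number from compound 1 to compound 4 (0.29 log units; within the scatter)), so the earlier loss on going to isopropoxy cannot be put down simply to the missing methoxy end. The sulfur-linked chain of compound 3 now has the lowest number against both groups linked through oxygen (a 4.8-fold higher number from compound 3 to compound 4 (0.68 log units; beyond the scatter); a 2.4-fold lower number from compound 1 to compound 3 (0.39 log units; beyond the scatter)), which shows that the link atom and chain together outperform either oxygen-linked group tested at this place.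

The compounds shown leave open whether that advantage belongs to the sulfur alone or to the sulfur together with the methoxy end, a question ethylsulfanyl on the same carbon would separate, and how an amine link or a longer chain would fare here. Nothing available gives a measured reason for any of these differences.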